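The source may hold more compounds than are shown below. What is called first, only, known or untested is meant among the compounds shown, and "the series" means these compounds.

Among the measured compounds shown here, the three compounds measured so far are all amides built on a piperidine. Compound 1, `COc1cc(N)c(Cl)cc1C(=O)NCC1CCNCC1`, links the piperidine to the amide nitrogen through a single saturated carbon, and in a functional assay on HEK293 cells for agonist activity at 5-hydroxytryptamine receptor 4 (Homo sapiens), read by cAMP accumulation (on this read-out higher numbers stand for an effect only at larger amounts of compound and lower numbers for an effect already at smaller amounts), compound 1 gives 398 nM. Compound 2, `COc1ccc2[nH]cc(C(=O)NC3CCNCC3)c2c1`, has a different acid part in its core, and in this assay compound 2 gives 100000000 nM, a number so large that no useful agonist effect appears. In compound 3, `CCCCCN1CCC(NC(=O)c2cc(Cl)c(N)cc2OC)CC1`, the amide nitrogen sits on a ring carbon of the piperidine and the ring nitrogen carries a pentyl chain; in this assay compound 3 gives 25.1 nM, the lowest of the three numbers, with compound 1 a clear step higher and compound 2 far beyond it, both gaps beyond the usual scatter.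

Compound 4, `COc1cc(N)c(Cl)cc1C(=O)NC1CCN(CCCCCN2C(=O)c3ccccc3C2=O)CC1`, differs from compound 3 by a group of 11 heavy atoms (8 carbon, 1 nitrogen, 2 oxygen; one five-membered non-aromatic ring with 1 hetero atom, one six-membered aromatic ring of carbon only) in place of a hydrogen atom, on a saturated chain carbon, five bonds along the chain from an amine nitrogen in a ring. For the measured compounds named here, no measured pair shows what such an addition does here, so the expectation rests on compound 3 alone, whose substituted ring nitrogen already accompanies the lowest number. The step from compound 3 to compound 4 is expected to be small, a 1.7-fold lower number from compound 3 to compound 4 (0.22 log units; within the scatter), leaning toward a lower number but not clearly beyond the scatter. For compound 4 in this assay the estimate is 15 nM, within the range 3 nM to 80 nM.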

Compound 4, half-maximal effective concentration: 5.01 nM
The estimate for compound 4 lay 3.0-fold (0.48 log units) above the measured number; the range from low to high includes it.
By their numbers in this assay, from the lowest: compound 4; then compound 3; then compound 1; then compound 2.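

In this assay the addition gives a 5.0-fold lower number from compound 3 to compound 4 (0.70 log units; beyond the scatter), so a saturated chain carbon, five bonds along the chain from an amine nitrogen in a ring, can carry a group of 11 heavy atoms, with one five-membered non-aromatic ring and one six-membered aromatic ring, and the number still falls. This is the first change in one place among the compounds shown, as the earlier ones differed in several places at once and could not show what a single change at this chain does. Nothing measured here explains the drop, so the result records what happens and gives no reason for it.

The compounds shown leave open which part of the added group goes with the lower number, the two carbonyl groups or the carbon-only aromatic ring. They also leave open whether something much smaller in the same place, such as an amine or a carboxylic acid, or a longer chain carrying the same group, would give a similar number.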